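The compounds below may be only part of what the source reports. "The series", "measured", "known", "first", "only" and "open" are said of these compounds alone.

Three compounds share one core and differ only in the aryl group attached to an oxygen on an aromatic ring. In a functional assay on HepG2 cells (Homo sapiens) for antiproliferative activity, read by MTT assay, with a stated time of 72 h (a higher number here means a weaker inhibitor, a lower number a stronger inhibitor), compound 1 `Cc1nn(C)c(Oc2ccc(F)cc2)c1/C=N\CCCCCCOc1cc2oc(=O)cc(C)c2cc1Cl` gives 12500 nM, compound 2 `Cc1nn(C)c(Oc2cccc(Cl)c2)c1/C=N\CCCCCCOc1cc2oc(=O)cc(C)c2cc1Cl` gives 6220 nM, and compound 3 `Cc1nn(C)c(Oc2ccc(Cl)cc2)c1/C=N\CCCCCCOc1cc2oc(=O)cc(C)c2cc1Cl` gives 2960 nM. Compound 3 stands lowest of the three in this assay; the step of a 2.1-fold lower number from compound 2 to compound 3 (0.32 log units; beyond the scatter) and the step of a 4.2-fold lower number from compound 1 to compound 3 (0.63 log units; beyond the scatter) are both beyond the scatter, so it is the strongest inhibitor measured here.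

Compound 4 `Cc1nn(C)c(Oc2cccc(Br)c2)c1/C=N\CCCCCCOc1cc2oc(=O)cc(C)c2cc1Cl` introduces the change (3-bromophenyl in place of 4-chlorophenyl on an oxygen on an aromatic ring). For the measured compounds named here, two measured steps bear on it. The step of a 2.1-fold lower number from compound 2 to compound 3 (0.32 log units; beyond the scatter) shows that moving a chlorine from a 3-chlorophenyl to a 4-chlorophenyl lowered the number, so returning to a 3-substituted ring may raise it again. The step of a 4.2-fold lower number from compound 1 to compound 3 (0.63 log units; beyond the scatter) shows that exchanging one halogen for another can also shift the number modestly. These pull in opposite directions, so compound 4 is expected to sit near compound 3, with a step of a 1.4-fold higher number from compound 3 to compound 4 (0.13 log units; within the scatter) that may not exceed the scatter. Compound 4 is estimated at 4000 nM, within a range from 1500 nM to 10000 nM.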

Compound 4, half-maximal inhibitory concentration: 6830 nM
Beside the measured number, compound 4's estimate is 1.7-fold (0.23 log units) below it; measured number inside the range.
By their numbers in this assay, from the lowest: compound 3; then compounds 2, 4 and 1 (each within the scatter of the next).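

In this assay, swapping the 4-chlorophenyl for 3-bromophenyl gives a 2.3-fold higher number from compound 3 to compound 4 (0.36 log units; beyond the scatter) and so costs activity, which leaves compound 3 the strongest inhibitor of the four. On the other side, the exchange of chloro for bromo on an otherwise identical ring gives a 1.1-fold higher number from compound 2 to compound 4 (0.04 log units; within the scatter) and so cannot be told apart from no change at all. The 3-bromophenyl also stays unresolved from the 4-fluorophenyl, with a 1.8-fold lower number from compound 1 to compound 4 (0.26 log units; within the scatter) as the step, so only the 4-chlorophenyl of compound 3 stands clearly apart so far.

Still open, as far as these compounds go, is whether a 4-bromophenyl would match the 4-chlorophenyl, and how a phenyl ring carrying an amine or a carboxylic acid would behave on the same oxygen. Nothing given here speaks to why compound 3 differs from the other three.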